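Swapping the pyrrolidin-1-yl group of compound 3

A few compounds are considered here, and "the series" means these few. Any claim that something is new, unique, unknown or untested is made for them only; others in the source may bear on it.

Of the compounds shown here, three built on a shared core have been measured in a functional assay on MIA PaCa-2 cells (Homo sapiens) for inhibition, read by MTT assay, with a stated time of 48 h, tested at 10 uM; on this read-out higher numbers stand for more inhibition of growth at the one concentration tested and lower numbers for less inhibition of growth. In this assay, compound 1 (`Cc1cc(=O)c2c(O)cc(OCc3ccccc3Br)c([C@H]3CCN(C)C[C@H]3O)c2o1`) gives 30%, compound 2 (`Cc1cc(=O)c2c(O)cc(O)c([C@H]3CCN(C)C[C@H]3OC(=O)c3ccco3)c2o1`) gives 13% and compound 3 (`Cc1cc(=O)c2c(O)c(CN3CCCC3)c(O)c([C@H]3CCN(C)C[C@H]3O)c2o1`) gives 28%. Compound 3 therefore stands within the scatter of compound 1 and beyond the scatter above compound 2.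

The next compound, compound 4 (`Cc1cc(=O)c2c(O)c(CN(C)CC(=O)O)c(O)c([C@H]3CCN(C)C[C@H]3O)c2o1`), carries (carboxymethyl)(methyl)amino in place of pyrrolidin-1-yl on a saturated chain carbon bound to an aromatic carbon. Among the measured compounds shown here, no pair of measured compounds differs in one place only, so the data offer no direct guide to the size of this step. A downward step in this assay is nevertheless expected, of a size close to the scatter, and a result with no real change would not be surprising. The estimated change is a number 12 percentage points lower from compound 3 to compound 4 (beyond the scatter). For compound 4 the estimated value is 16%, with an expected range from 3% to 32%.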

Compound 4, percent growth inhibition at one concentration: 16%
Beside the measured number, compound 4's estimate shows no gap at the digits printed, and the stated range covers the measured number.
By their numbers in this assay, from the lowest: compounds 2 and 4 (each within the scatter of the next); then compounds 3 and 1 (each within the scatter of the next).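

In this assay, among the compounds shown here, this is the first pair differing in one place, and it shows that the group on a saturated chain carbon bound to an aromatic carbon matters to growth inhibition: replacing pyrrolidin-1-yl with (carboxymethyl)(methyl)amino gives a number 12 percentage points lower from compound 3 to compound 4 (beyond the scatter) and marks a modest loss. The step removes the ring and adds the carboxylic acid together, so the two compounds cannot separate the contribution of either change. No supporting measurement accounts for the loss.

On these data alone, it remains open whether an open-chain dimethylamino group without the acid would keep the level of compound 3, which would point to the acid as the source of the step. The methyl ester or the primary amide of the carboxylic acid, and a piperidin-1-yl ring, also remain to be placed at this position.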